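Methylation of a Dihydroxybiphenyl: Expected Loss of Cytotoxicity

This account rests on a few compounds, and the source may have more. Where it says the series, first, only, none or still open, it means among the compounds named here.

Measured compounds:
compound 1, `Oc1ccc(-c2cccc(O)c2)cc1`: 3.4 ug/mL
compound 2, `COc1ccc(-c2cccc(O)c2)cc1`: 72 ug/mL

Compound 1 gives the lowest number of the two measured in a functional assay on HT-29 cells (Homo sapiens) for cytotoxicity, read by MTT assay, with a stated time of 3 days; a higher number here means a weaker inhibitor, a lower number a stronger inhibitor; its nearest neighbour is compound 2, where the value is 72 ug/mL. Going by the values given here, the step of a 21-fold higher number from compound 1 to compound 2 (1.33 log units; beyond the scatter) is the only measured step, and it is large: methyl in place of hydrogen on an oxygen on an aromatic ring.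

Compound 3, `COc1cccc(-c2ccc(O)cc2)c1`, has not yet been measured in this assay. It differs from compound 1 as follows: methyl in place of hydrogen on an oxygen on an aromatic ring. This is the same kind of change that was seen in the step from compound 1 to compound 2, so a step in the same direction is expected, of a size comparable to that one, given a 21-fold higher number from compound 1 to compound 2 (1.33 log units; beyond the scatter). Compound 3 is therefore expected to give a higher number than compound 1, about a 12-fold higher number from compound 1 to compound 3 (1.07 log units; beyond the scatter). The estimate for compound 3 in this assay is 40 ug/mL, within a range from 10 ug/mL to 120 ug/mL.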

Compound 3, half-maximal inhibitory concentration: 24 ug/mL
For compound 3 the middle estimate is 1.7-fold (0.22 log units) above the measured one, within the range that was stated.
By their numbers in this assay, from the lowest: compound 1; then compound 3; then compound 2.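

In this assay, hydroxy to methoxy on the second oxygen of the shared core also gives a higher number, with a 7.1-fold higher number from compound 1 to compound 3 (0.85 log units; beyond the scatter) as a modest step. Set beside the large step of a 21-fold higher number from compound 1 to compound 2 (1.33 log units; beyond the scatter) in the same assay, this shows that methyl in place of hydrogen raises the number on either oxygen on an aromatic ring, and that the direction of the change holds while its printed size differs between the two places. Nothing among the data given accounts for either step or for the difference in their sizes.

Left open is whether methyl on both oxygens would raise the number further than either single change. Also open, as far as these compounds go, is how a longer chain such as ethyl on either oxygen, or an amine in place of either hydroxy, would read against compound 1 in this cell assay.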